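The source may hold more compounds than are shown below. What is called first, only, known or untested is meant among the compounds shown, and "the series" means these compounds.

Compound 1 `CCCN(CC1CC1)c1cc(C(C)(C)c2c(OC)cc(OC)cc2OC)nc(C)n1`: in an assay on isolated protein for binding affinity to corticotropin-releasing factor receptor 1 (Homo sapiens) (on this read-out higher numbers stand for weaker inhibition and lower numbers for stronger inhibition), compound 1 reaches only a limit, > 10000 nM.
Compound 2 `CCCN(CC1CC1)c1cc(C(O)c2c(CC)cc(CC)cc2CC)nc(C)n1`: compound 2 gives 360 nM.
Compound 3 `CCCN(CC1CC1)c1cc(C(C)(O)c2c(OC)cc(OC)cc2OC)nc(C)n1`: compound 3 gives 1900 nM.

Compound 2 holds the lowest of the two real numbers; its nearest neighbour is compound 3, which sits beyond the scatter above it. Compound 4 `CCCN(CC1CC1)c1cc(C(OC)c2c(CC)cc(CC)cc2CC)nc(C)n1` differs from compound 2 by methyl in place of hydrogen on an oxygen on a saturated carbon. Within the data shown here, the one measured step, an at least 5.2-fold lower number from compound 1 to compound 3 (0.72 log units; beyond the scatter), concerns the same carbon but swaps methyl against hydroxy and starts from a limit (the limit of > 10000 nM in this assay, at which 1 of the 3 values shown sits), so it only hints that the hydroxy carbon matters. For the methyl cap on oxygen the expectation is a weakening of roughly a 3.3-fold higher number from compound 2 to compound 4 (0.52 log units; beyond the scatter). Compound 4 is therefore estimated at 1200 nM, plausibly between 300 nM and 5000 nM.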

Compound 4, inhibition constant: 90 nM
The estimate for compound 4 lay 13-fold (1.12 log units) above the measured number; measured number below the stated range.
By their numbers in this assay, from the lowest: compound 4; then compound 2; then compound 3. At a limit, above all of these: compound 1.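

In this assay, replacing the hydrogen on this oxygen with methyl gives a 4.0-fold lower number from compound 2 to compound 4 (0.60 log units; beyond the scatter), so on the triethyl-bearing core of compound 2 a free hydroxy is not needed for a low number, and methoxy does better. The values shown offer no measured explanation for this gain. Going by these compounds, whether an ethyl or longer chain on this oxygen, or an amine in place of the hydroxy, would lower the number further remains open. So does whether the same change would act alike on compound 3.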